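A Carboxypyridinyl for a Methoxypyridinyl: Solubility Outlook

The source may hold more compounds than are shown below. What is called first, only, known or untested is meant among the compounds shown, and "the series" means these compounds.

Compound 1 `COc1ccnc(Nc2cc3[nH]c(-c4cccc(C(F)(F)F)c4)nc3cn2)c1`: < 5000 nM
Compound 2 `Fc1ccc(-c2nc3cnc(Nc4ccccn4)cc3[nH]2)cc1C(F)(F)F`: < 5000 nM
Compound 3 `Fc1ccc(Nc2cc3[nH]c(-c4ccc(F)c(C(F)(F)F)c4)nc3cn2)nc1`: < 5000 nM

Of the compounds shown here, three sharing one core have been measured in a physicochemical assay for solubility, using the shake flask method, in phosphate buffer, measured as kinetic solubility, with a stated time of 20 h, at pH 6.5; a higher number here means a more soluble compound, a lower number a less soluble compound. Compound 1 sits at a limit of the assay, < 5000 nM, rather than at a number. Compound 2 likewise returns only a limit, < 5000 nM. Compound 3 also gives a limit, < 5000 nM. Within the data shown here, the only single change among the measured compounds, a step that the two limits leave unreadable from compound 2 to compound 3, is fluoro in place of hydrogen on an aromatic carbon, and its size cannot be read from two limits. Across the set, the limit of < 5000 nM in this assay, at which 3 of the 3 values shown sit, is all that the measurements show, so nothing about compound 1's true position is known beyond that limit.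

Compound 4 `O=C(O)c1ccc(Nc2cc3[nH]c(-c4cccc(C(F)(F)F)c4)nc3cn2)nc1` has not been measured. It differs from compound 1 by 5-carboxypyridin-2-yl in place of 4-methoxypyridin-2-yl on a nitrogen on an aromatic ring. Among the measured compounds shown here, no measured step touches the nitrogen on an aromatic ring where this change sits, and no measured step in this assay is readable at all, so no size or direction can be drawn from the data for the move from compound 1 to compound 4. The step is therefore expected only as an estimate, an at least 4.0-fold higher number from compound 1 to compound 4 (0.60 log units; beyond the scatter), without support from measured steps. Compound 4 is estimated to give 20000 nM in this assay, within a range from 3000 nM to 150000 nM, with a real chance that the assay again reports only a limit.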

Compound 4, solubility: 6000 nM
The estimate for compound 4 lay 3.3-fold (0.52 log units) above the measured number; measured number inside the range.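

In this assay, compound 4 is the only compound shown that returns a number rather than a limit, so the nitrogen on an aromatic ring is a place where a change of group can bring a reading within the range of the assay. Setting 5-carboxypyridin-2-yl in place of 4-methoxypyridin-2-yl there gives an at least 1.2-fold higher number from compound 1 to compound 4 (0.07 log units; that floor lies within the scatter), which is a floor and not a full size, and that floor alone does not establish a gain beyond the usual scatter. The true size of this step stays unread, and the other step shown between measured compounds still cannot be read, because nearly every other value is only a limit: the limit of < 5000 nM in this assay, at which 3 of the 4 values shown sit.

The compounds shown leave open how much of the step comes from the carboxy group itself and how much from the loss of the methoxy group, since the two groups differ in more than one respect. They also leave open whether an amine or a primary amide carried on the same pyridinyl ring would return a number in this assay or fall back to a limit.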